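This account rests on a few compounds, and the source may have more. Where it says the series, first, only, none or still open, it means among the compounds named here.

Working notes on the series. In a functional assay on A498 cells (Homo sapiens) for inhibition, read by sulforhodamine B assay, with a stated time of 48 h, tested at 10 uM (on this read-out higher numbers stand for more inhibition at the one concentration tested (going by the name of the read-out) and lower numbers for less inhibition), compound 1 `c1ccc(-c2cn3ccnc3c(-c3ccc4ncn(C5CCCCC5)c4c3)n2)cc1` gives 26.1%, and compound 2 `c1ccc2c(-c3cn4ccnc4c(-c4ccc5ncn(C6CCCCC6)c5c4)n3)cccc2c1` gives 14%. The one measured step, a number 12.1 percentage points lower from compound 1 to compound 2 (beyond the scatter), is the only change in this assay so far, and compound 2 is therefore the lower of the two numbers shown, its nearest neighbour being compound 1 with a higher value beyond the scatter.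

Compound 3 `c1cn2cc(-c3ccsc3)nc(-c3ccc4ncn(C5CCCCC5)c4c3)c2n1` follows from compound 2 by the change (thiophen-3-yl in place of naphthalen-1-yl on an aromatic carbon). The measured step bears on it only indirectly: the larger aryl group that lowered the number from compound 1 to compound 2 now leaves again, and a smaller ring enters in its place. Within the data shown here, no step for thiophen-3-yl is known in this assay. The expectation is a step upward from compound 2 of about a number 8 percentage points higher from compound 2 to compound 3 (within the scatter), roughly back toward the level of compound 1, because of the drop seen in a number 12.1 percentage points lower from compound 1 to compound 2 (beyond the scatter). For compound 3 the estimate in this assay is 22%, within a range of 5% to 40%.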

Compound 3, a percentage reported as inhibition, at one concentration (the size of the read-out at that concentration, not a potency): 20.1%
Estimate against measurement, compound 3: 1.9 percentage points above, within the range that was stated.
By their numbers in this assay, from the lowest: compounds 2, 3 and 1 (each within the scatter of the next, the first and the last beyond it).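

In this assay, thiophen-3-yl on this aromatic carbon separates from neither aryl group already seen: both a number 6.1 percentage points higher from compound 2 to compound 3 (within the scatter) and a number 6 percentage points lower from compound 1 to compound 3 (within the scatter) stay inside the usual variation, although phenyl and naphthalen-1-yl differ beyond it. This place therefore accepts a five-membered aromatic ring with one sulfur, and the three compounds give no grounds for ordering thiophen-3-yl against either of the other groups. Nothing available accounts for these numbers.

As far as these compounds go, it remains open whether an amine, a carboxylic acid or a longer chain on this same carbon would take the number clearly away from the level of these aryl compounds. From the compounds shown here alone, it is also open whether thiophen-2-yl or pyridin-3-yl would behave as thiophen-3-yl does here.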